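The source may hold more compounds than are shown below. What is called first, only, known or untested is meant among the compounds shown, and "the series" means these compounds.

Compound 2 `Cc1nc(N2CCC(N3C(=O)CCC3=O)CC2)nc2ccc(NC(=O)/C=C/c3ccc(OC(F)(F)F)cc3)cc12` gives 35 nM in a functional assay on CHO-K1 cells for antagonist activity at melanin-concentrating hormone receptor 1 (Homo sapiens), read by inositol phosphate accumulation, with stated times of 10 min and 45 min (on this read-out higher numbers stand for weaker inhibition and lower numbers for stronger inhibition), the lowest of the three numbers recorded for this series. Compound 1 `Cc1ccc(/C=C/C(=O)Nc2ccc3nc(N4CCC(O)(C5CC5)CC4)nc(C)c3c2)cc1` gives 107 nM in this assay, and compound 3 `C/C(=C\C(=O)Nc1ccc2nc(N3CCC(O)(C4CC4)CC3)nc(C)c2c1)c1ccc(Cl)cc1` gives 340 nM; the gaps from compound 2 to compound 1 and to compound 3 are both beyond the scatter, so compound 2 stands as the most potent of the three. Going by the values given here, the only step between measured compounds that differ in one place is a 3.2-fold higher number from compound 1 to compound 3 (0.50 log units; beyond the scatter), and it concerns the group on the carbonyl carbon, not the substituent carried by the six-membered non-aromatic ring with one nitrogen.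

Compound 4 `Cc1nc(N2CCC(N3CCCS3(=O)=O)CC2)nc2ccc(NC(=O)/C=C/c3ccc(OC(F)(F)F)cc3)cc12` has not yet been measured in this assay. It differs from compound 2 by a group of 7 heavy atoms (3 carbon, 1 nitrogen, 2 oxygen, 1 sulfur; one five-membered non-aromatic ring with 2 hetero atoms) in place of a group of 7 heavy atoms (4 carbon, 1 nitrogen, 2 oxygen; one five-membered non-aromatic ring with 1 hetero atom), on a saturated ring carbon. Among the compounds with values here, no measured step touches this position, so nothing recorded bears directly on the change, and the measured step between compound 1 and compound 3 offers no guidance here. The leaving and entering groups are alike in size and in their counted donors and acceptors, so the expected step in this assay is small, at most a modest weakening, and may well fall within the scatter. The step expected is a 1.4-fold higher number from compound 2 to compound 4 (0.15 log units; within the scatter). Compound 4 is estimated at 50 nM, with a range from 15 nM to 170 nM.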

Compound 4, half-maximal inhibitory concentration: 16 nM
The estimate for compound 4 lay 3.1-fold (0.49 log units) above the measured number; measured number inside the range.
By their numbers in this assay, from the lowest: compound 4; then compound 2; then compound 1; then compound 3.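

At the saturated ring carbon of the six-membered non-aromatic ring with 1 nitrogen, the substituent proves able to move the number: in this assay, replacing the 2,5-dioxopyrrolidin-1-yl group with the sulfur-containing five-membered ring gives a 2.2-fold lower number from compound 2 to compound 4 (0.34 log units; beyond the scatter) and this modest step lies beyond the scatter. The two groups match in heavy atoms, double bonds outside aromatic rings, hydrogen-bond donors, hydrogen-bond acceptors and net charge, and differ in the atoms themselves, the entering group holding one sulfur and one carbon fewer, so these matching counts do not by themselves fix the number at this position. Nothing in the available data accounts for the direction or the size of this step.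

As far as these compounds go, whether the step depends on the sulfur, on the ring or on both stays open, as does the outcome with a six-membered ring, an open-chain acetamide or a primary amine on the same carbon. It is also unknown whether the same replacement would give a similar step with the 2-(4-methylphenyl)ethenyl group on the carbonyl carbon of compound 1 in place of the trifluoromethoxyphenyl side chain shared by compound 2 and compound 4.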